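The compounds below may be only part of what the source reports. "The series", "measured", "known", "first", "only" and "open" are said of these compounds alone.

Measured so far in a functional assay on SK-N-SH cells (Homo sapiens) for inhibition, read by MTT assay; on this read-out higher numbers stand for weaker inhibition and lower numbers for stronger inhibition:
- compound 1 `CCCCCCCCCCn1cc(/C=C/C(=O)c2ccc(NC(=O)CN3CCC(Cc4ccccc4)CC3)cc2)nn1`: 33300 nM
- compound 2 `CC(C)(C)OC(=O)N1CCN(CC(=O)Nc2ccc(C(=O)/C=C/c3cn(Cc4ccc(Br)cc4)nn3)cc2)CC1`: 25800 nM
- compound 3 `CCCCCCCCCCn1cc(/C=C/C(=O)c2ccc(NC(=O)CN3CCN(c4ccccc4)CC3)cc2)nn1`: 39500 nM

All three numbers sit at the weak end of the scale. Compound 2 has the lowest of the three, but its gaps to compound 1 and to compound 3 are both within the usual scatter, so the three read as a single level rather than as an order. Among the measured compounds shown here, no pair among them differs in only one place, so no single-step comparison is available within the measured set.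

The next compound, compound 4 `CCCCCCCCn1cc(/C=C/C(=O)c2ccc(NC(=O)CN3CCN(C(=O)OC(C)(C)C)CC3)cc2)nn1`, is reached from compound 2 by the change (heptyl in place of 4-bromophenyl on a saturated chain carbon bound to an aromatic nitrogen). Cut one bond further out, the same difference reads 4-bromobenzyl to octyl. Compound 1 and compound 3 carry an open chain at the same saturated chain carbon bound to an aromatic nitrogen, and their numbers in this assay lie together with that of compound 2, so the measured set gives no sign that a chain in place of the aromatic group moves the number beyond the scatter in either direction. The step from compound 2 to compound 4 is therefore expected to be small, a 1.2-fold higher number from compound 2 to compound 4 (0.09 log units; within the scatter), with no direction favoured. For compound 4 the estimate is 32000 nM, within 13000 nM to 80000 nM.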

Compound 4, half-maximal inhibitory concentration: 38000 nM
Compound 4: middle estimate off by 1.2-fold (0.07 log units), on the low side; the range from low to high includes it.
By their numbers in this assay, from the lowest: compounds 2, 1, 4 and 3 (each within the scatter of the next).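

In this assay, among the compounds shown here, the exchange at the saturated chain carbon bound to an aromatic nitrogen gives a 1.5-fold higher number from compound 2 to compound 4 (0.17 log units; within the scatter) and thus provides the first single-place comparison. With heptyl in place of 4-bromophenyl, read one bond further out as 4-bromobenzyl to octyl, the aromatic ring and its bromine can be replaced by an open chain with no shift beyond the scatter, and the number remains at the weak end of the scale. Compound 1 and compound 3 could suggest this only indirectly, as each differs from compound 2 in more than one place, and no measurement on hand offers an explanation for the result.

This single step leaves open whether any group at this carbon can move the number beyond the scatter, for example a short ethyl chain, a longer chain ending in a carboxylic acid or an amine, or a benzyl group without bromine. Also open, going by these compounds, is whether a free amine in place of the tert-butyl carbamate would shift the level on the octyl compound.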